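This account rests on a few compounds, and the source may have more. Where it says the series, first, only, none or still open, it means among the compounds named here.

Measured compounds in a functional assay on A549 cells (Homo sapiens) for cytotoxicity, read by MTT assay, with a stated time of 24 h; a lower number here means a stronger inhibitor, a higher number a weaker inhibitor:
- compound 1 `CC(=O)OC[C@H]1O[C@H](NS(N)(=O)=O)C=C[C@@H]1OC(C)=O`: 704000000 nM
- compound 2 `CC(=O)OC[C@H]1O[C@H](NS(=O)(=O)c2ccc(C)cc2)C(OC(C)=O)=C[C@@H]1OC(C)=O`: 34900000 nM
- compound 3 `CC(=O)OC[C@H]1O[C@H](NS(N)(=O)=O)C=C[C@H]1OC(C)=O`: 558000000 nM

Compound 3 stands second highest of the three numbers in this assay. Its nearest neighbour is compound 1, and the step from compound 1 to compound 3 is a 1.3-fold lower number from compound 1 to compound 3 (0.10 log units; within the scatter); the two differ only in configuration (the fact that compounds 1 and 3 differ only in the configuration as drawn), so the change of drawn stereochemistry leaves the number essentially unchanged. Within the data shown here, compound 2 gives the lowest number of the three, beyond the scatter from compound 3, but it differs from compound 3 in more than one place and no single step connects them.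

Compound 4 `CCS(=O)(=O)N[C@@H]1C=C[C@@H](OC(C)=O)[C@@H](COC(C)=O)O1` is not yet measured. It differs from compound 3 by ethyl in place of amino on a sulfonyl sulfur. Among the measured compounds shown here, none of the measured steps touches the sulfonyl substituent: the only single-change step, from compound 1 to compound 3, concerns configuration alone and lies within the scatter. The values of compound 2 and compound 3 only show that a different sulfonyl group, combined with a further change, went with a lower number in this assay. The expectation for compound 4 is therefore loosely held: a step of a 1.9-fold lower number from compound 3 to compound 4 (0.27 log units; within the scatter) is estimated, in the direction of a lower number, with a wide range. Compound 4 is expected to give about 300000000 nM in this assay, between 60000000 nM and 1500000000 nM.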

Compound 4, half-maximal inhibitory concentration: > 1000000000 nM
Compound 4 ended at the assay's limit (the forecaster's own chance of this, stated with the estimate: 20%); at least 3.3-fold (0.52 log units) between middle value and limit.
By their numbers in this assay, from the lowest: compound 2; then compounds 3 and 1 (each within the scatter of the next). At a limit, above all of these: compound 4.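

In this assay compound 4 stands at a limit of the assay (> 1000000000 nM), and this value is a limit, not a number. Ethyl in place of amino on a sulfonyl sulfur gives an at least 1.7-fold higher number from compound 3 to compound 4 (0.25 log units; that floor lies within the scatter) as the first single-change reading at this position, and the change, which takes away the hydrogen-bond donor of the amino group, brings no lower number. On these data alone, only a floor can be stated for this step, so it remains unknown whether the true gap lies beyond the scatter: the limit of > 1000000000 nM in this assay, at which 1 of the 4 values shown sits.

As far as these compounds go, whether a methyl group, a propyl chain or a dimethylamino group on the same sulfonyl sulfur would give a number within the measurable range remains open, as does the effect of ethyl in the drawn configuration of compound 1. Among these compounds, no single step connects compound 2 to compound 3, so it also remains open whether the lower number of compound 2 goes with its sulfonyl group or with its further change.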